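The source may report more compounds than this note shows. Statements on the series, on what has been measured and on what is new or still open speak of the compounds shown alone.

Measured so far:
compound 1 `NCCCC[C@H](NC(=O)CN(c1nc(Cl)nc2[nH]cnc12)C1CC1)C(=O)OCc1ccccc1`: 41.2%
compound 2 `CC(C)[C@H](NC(=O)CN(c1nc(Cl)nc2[nH]cnc12)C1CC1)C(=O)O`: 38.8%

In a functional assay on the whole organism (Tail, strain ICR) with Mus musculus as the target, in the tail flick test, with a stated time of 60 min, at a dose of 25 umol/kg by the oral route (on this read-out lower numbers stand for a weaker effect and higher numbers for a stronger effect at the one dose given), compound 1 has the larger of the two numbers, but its gap to compound 2 lies within the usual scatter, so the two cannot be told apart. Compound 3 `C[C@@H](O)[C@H](NC(=O)CN(c1nc(Cl)nc2[nH]cnc12)C1CC1)C(=O)OCc1ccccc1` has not been measured. It differs from compound 1 in one place: 1-hydroxyethyl in place of 4-aminobutyl on a saturated chain carbon bound to an amide-type nitrogen and a carbonyl carbon. Among the compounds with values here, no measured pair shows this kind of change, so there is no basis for expecting a step beyond the scatter in either direction; the expected step is a number 1.2 percentage points lower from compound 1 to compound 3 (within the scatter). Compound 3 is therefore estimated at 40%, with a range from 20% to 60%.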

Compound 3, a percentage reported as activity, at one dose (the size of the read-out at that dose, not a potency): 29.7%
Compound 3: the middle estimate sits 10.3 percentage points above what was measured, and the stated range covers the measured number.
By their numbers in this assay, from the lowest: compounds 3, 2 and 1 (each within the scatter of the next, the first and the last beyond it).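

In this assay the side chain on this saturated chain carbon matters: 1-hydroxyethyl in place of 4-aminobutyl gives a number 11.5 percentage points lower from compound 1 to compound 3 (beyond the scatter) at the one dose tested, a modest but real step. This single change shortens the chain, swaps the amine for a hydroxyl and adds a defined stereocentre, and these cannot be separated here. No measurement shown explains the step.

Going by these compounds, whether a 4-hydroxybutyl chain or a plain butyl chain would keep the higher number remains open, and either would show whether the length of the chain or its end group counts.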